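A stereochemical switch on a saturated ring

This account rests on a few compounds, and the source may have more. Where it says the series, first, only, none or still open, it means among the compounds named here.

Three compounds share a pyrazolopyrimidine-type amine core and were tested in an assay on isolated protein for inhibition of eIF-2-alpha kinase GCN2 (Homo sapiens); a higher number here means a weaker inhibitor, a lower number a stronger inhibitor. Compound 1 `CCn1cc(Nc2ncc3c(C)nn(-c4ccc(OC)cc4)c3n2)cn1` gives 81 nM in this assay. Compound 2 `COCCNC(=O)CNc1ncc2c(Br)nn(-c3ccc4ncccc4c3)c2n1` reaches only the limit of the measurement, > 1000 nM, which is a limit of this assay and not a number; it is the one case described by the limit of > 1000 nM in this assay, at which 1 of the 3 values shown sits. Compound 3 `COCCNC(=O)[C@@H]1CC[C@H](Nc2ncc3c(Br)nn(-c4ccc5ncccc5c4)c3n2)C1` gives 923 nM in this assay, the highest of the two numbers recorded; its nearest neighbour is compound 1, whose number is lower by a margin beyond the usual scatter.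

Compound 4 `COCCNC(=O)[C@@H]1CC[C@@H](Nc2ncc3c(Br)nn(-c4ccc5ncccc5c4)c3n2)C1` is the next step. Its difference from compound 3 is the two compounds have the same atoms and bonds and differ only in configuration as drawn: 1 of 2 stereo elements differ; a stereocentre at a saturated ring carbon is drawn S in compound 3 and R in compound 4. Among the measured compounds shown here, no measured pair here changes only a stereocentre, so the direction of this step cannot be read from the data. Compound 4 is expected to sit near compound 3, with a step of a 1.3-fold lower number from compound 3 to compound 4 (0.12 log units; within the scatter) in this assay. The estimate for compound 4 is 700 nM, within a range from 150 nM to 4000 nM.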

Compound 4, half-maximal inhibitory concentration: 5 nM
Compound 4: the middle estimate sits 140-fold (2.15 log units) above what was measured, and the stated range ends above it.
By their numbers in this assay, from the lowest: compound 4; then compound 1; then compound 3. At a limit, above all of these: compound 2.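

Changing only the stereocentre at a saturated ring carbon from S to R gives a 180-fold lower number from compound 3 to compound 4 (2.27 log units; beyond the scatter) in this assay. This is the first pair shown in which a single configurational change can be read directly, and it shows that the drawn configuration at this one carbon matters greatly for this pair, even though the atoms and bonds stay the same. The whole step can be assigned to that inversion because no other structural change accompanies it: the fact that compounds 3 and 4 differ only in the configuration as drawn

The compounds shown leave open how the other stereo element on the ring affects the number, since it is the same in compound 3 and compound 4. They also do not show whether the R configuration would keep its large effect if the amide side chain gave way to a carboxylic acid or a primary amine.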